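The source may hold more compounds than are shown below. What is called first, only, known or untested is meant among the compounds shown, and "the series" means these compounds.

Measured so far in a physicochemical assay for lipophilicity, using the shake flask method; on this read-out higher numbers stand for higher lipophilicity and lower numbers for lower lipophilicity

Compound 1 `Nc1ncnc(Oc2ccc(NC(=O)C3(C(=O)Nc4ccc(F)cc4)CC3)cc2F)c1/C=N/OC1CCCCC1` gives 4.69
Compound 2 `Nc1ncnc(Oc2ccc(NC(=O)C3(C(=O)Nc4ccc(F)cc4)CC3)cc2F)c1/C=N/OCCCN1CCCC1` gives 3.82
Compound 3 `Nc1ncnc(Oc2ccc(NC(=O)C3(C(=O)Nc4ccc(F)cc4)CC3)cc2F)c1/C=N/OCC(=O)N1CCOCC1` gives 2.1

Compound 3 has the lowest of these three numbers, beyond the scatter from both others. Compound 4 `CC(O)CO/N=C/c1c(N)ncnc1Oc1ccc(NC(=O)C2(C(=O)Nc3ccc(F)cc3)CC2)cc1F` differs from it in one place (1-hydroxyethyl in place of (morpholin-4-yl)carbonyl on a saturated chain carbon bound to an oxygen), with 1-hydroxyethyl in place of (morpholin-4-yl)carbonyl on a saturated chain carbon bound to an oxygen. Both a number 2.59 log units lower from compound 1 to compound 3 (beyond the scatter) and a number 1.72 log units lower from compound 2 to compound 3 (beyond the scatter) were large steps that led to the (morpholin-4-yl)carbonyl group. Among the compounds with values here, no measured step shows 1-hydroxyethyl itself, so only part of that drop is expected to be recovered. A modest upward move in this assay is therefore expected (a number 0.80 log units higher from compound 3 to compound 4 (beyond the scatter)). The estimated value for compound 4 is 2.9 (expected range 2.4 to 3.4).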

Compound 4, partition coefficient: 2.75
Compound 4: the middle estimate sits 0.15 log units above what was measured; the range from low to high includes it.
By their numbers in this assay, from the lowest: compound 3; then compound 4; then compound 2; then compound 1.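

In this assay, 1-hydroxyethyl in place of (morpholin-4-yl)carbonyl on this saturated chain carbon gives a number 0.65 log units higher from compound 3 to compound 4 (beyond the scatter), so a much smaller group without a ring does not read lowest here. That group still reads well under the other two, with a number 1.07 log units lower from compound 2 to compound 4 (beyond the scatter) and a number 1.94 log units lower from compound 1 to compound 4 (beyond the scatter), which places 2-hydroxypropyl between the morpholine amide chain and the pyrrolidine chain. Nothing available explains these shifts.

Still open, as far as these compounds go, is whether a carboxylic acid at this place would read below compound 3 , and whether a longer chain ending in a hydroxyl would stay near compound 4 .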